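Aryl variation on the carbonyl carbon: outlook for compound 4

The source may hold more compounds than are shown below. What is called first, only, known or untested is meant among the compounds shown, and "the series" means these compounds.

Of the compounds shown here, three sharing one core have been measured in a functional assay on MCF7 cells (Homo sapiens) for antiproliferative activity, read by XTT assay, with a stated time of 72 h; a higher number here means a weaker inhibitor, a lower number a stronger inhibitor. Compound 1 `COc1ccc(-c2cc3ccccc3nc2/C=C/C(=O)c2ccccc2)cc1` gives 4040 nM, the lowest of the three numbers. Compound 2 `COc1ccc(-c2cc3ccccc3nc2/C=C/C(=O)c2ccc(OC)c(OC)c2)cc1` gives 6030 nM, and compound 3 `COc1ccc(-c2cc3ccccc3nc2/C=C/C(=O)c2ccc(N)cc2)cc1` gives 6920 nM. Both measured steps from compound 1 alter only the aryl group on the carbonyl carbon: a 1.5-fold higher number from compound 1 to compound 2 (0.17 log units; within the scatter) and a 1.7-fold higher number from compound 1 to compound 3 (0.23 log units; within the scatter), each within the scatter. The two analogues also sit within the scatter of each other, a 1.1-fold higher number from compound 2 to compound 3 (0.06 log units; within the scatter).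

Compound 4 `COc1ccc(-c2cc3ccccc3nc2/C=C/C(=O)c2ccc(Br)s2)cc1` has not been measured. It differs from compound 1 in the same place: 5-bromothiophen-2-yl in place of phenyl on a carbonyl carbon. For the measured compounds named here, the steps that bear on this change, the step to compound 2 and the step to compound 3, both stayed within the scatter, so no step beyond the scatter is expected in this assay in either direction, while no measured compound carries a heteroaryl or a bromine at this place, which widens the range. The expected step is a 1.1-fold higher number from compound 1 to compound 4 (0.05 log units; within the scatter). Compound 4 is therefore estimated at 4500 nM, within 2000 nM to 10000 nM.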

Compound 4, half-maximal inhibitory concentration: 910 nM
The estimate for compound 4 lay 4.9-fold (0.69 log units) above the measured number; measured number outside the range, below it.
By their numbers in this assay, from the lowest: compound 4; then compounds 1, 2 and 3 (each within the scatter of the next).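

In this assay, the aryl group on the carbonyl carbon now gives a step beyond the scatter, a 4.4-fold lower number from compound 1 to compound 4 (0.65 log units; beyond the scatter), which the earlier changes at this place did not. The gap is also beyond the scatter against the other two aryl groups, a 6.6-fold lower number from compound 2 to compound 4 (0.82 log units; beyond the scatter) and a 7.6-fold lower number from compound 3 to compound 4 (0.88 log units; beyond the scatter), so compound 4 stands apart from the three compounds with a six-membered aromatic ring, which remain within the scatter of each other. The change replaces the ring and introduces bromine in one step, and no data are available that explain the step.

The compounds shown leave open how the step divides between ring and halogen, which an unsubstituted thiophene and a bromophenyl group would separate. Going by these compounds, whether a furan or a chlorothiophene at this place gives a similar number also remains open.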